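Dimethylamino to Diethylamino on Two Related Cores

This account rests on a few compounds, and the source may have more. Where it says the series, first, only, none or still open, it means among the compounds named here.

Measured compounds:
Compound 1 `CN(C)CCCCn1c(N)c(-c2nc3cc(Cl)ccc3[nH]2)c2nc(C#N)c(C#N)nc21`: 3120 nM
Compound 2 `CCN(CC)CCCCn1c(N)c(-c2nc3cc(Cl)ccc3[nH]2)c2nc(C#N)c(C#N)nc21`: 3640 nM
Compound 3 `CN(C)CCCCn1c(-c2c(N)n(C)c3nc(C#N)c(C#N)nc23)nc2ccccc21`: 10100 nM

All three were tested in a functional assay on HeLa cells (Homo sapiens) for antiproliferative activity, read by MTT assay, with a stated time of 48 h; on this read-out higher numbers stand for weaker inhibition and lower numbers for stronger inhibition. Compound 1 and compound 2 share one core and differ only in one place: diethylamino in place of dimethylamino on a saturated chain carbon, four bonds along the chain from an aromatic nitrogen. The step of a 1.2-fold higher number from compound 1 to compound 2 (0.07 log units; within the scatter) shows that this change made no difference that can be told from repeat scatter.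

Compound 3 is built on a different core. The difference between the two cores is not broken down here. In this assay compound 3 gives the highest number of the three, and its distance from compound 2 and from compound 1 is in both cases beyond the scatter, so compound 3 is the weakest inhibitor of the three measured.

Compound 4 `CCN(CC)CCCCn1c(-c2c(N)n(C)c3nc(C#N)c(C#N)nc23)nc2ccccc21` has not yet been measured. Among the measured compounds shown here, it is related to compound 3 by diethylamino in place of dimethylamino on a saturated chain carbon, four bonds along the chain from an aromatic nitrogen, which is the same change, in the same place, as the one from compound 1 to compound 2. Because that earlier step a 1.2-fold higher number from compound 1 to compound 2 (0.07 log units; within the scatter) was within the scatter, the corresponding step is expected to be small as well, and compound 4 is expected to stay near compound 3. The expected step is a 1.1-fold higher number from compound 3 to compound 4 (0.06 log units; within the scatter). For the measured compounds named here, for compound 4 the estimate in this assay is 11500 nM, with a likely range from 6000 nM to 22000 nM, the width reflecting that only one earlier example of this change, on a different core, is available.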

Compound 4, half-maximal inhibitory concentration: 11800 nM
For compound 4 the middle estimate is 1.0-fold (0.01 log units) below the measured one; the range from low to high includes it.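

On the second core, diethylamino in place of dimethylamino gives a 1.2-fold higher number from compound 3 to compound 4 (0.07 log units; within the scatter) in this assay, so compound 3 and compound 4 cannot be told apart from the ordinary spread of repeated measurements. Set beside the earlier case on the other core, the two steps agree: the same change on two cores in this assay, a 1.2-fold higher number (0.07 log units; within the scatter) from compound 1 to compound 2 and a 1.2-fold higher number (0.07 log units; within the scatter) from compound 3 to compound 4, 1.0-fold (0.00 log units) apart, within the scatter of two such steps

This shows that, in these two pairs, the swap at this place on the chain leaves the antiproliferative read-out in these cells indistinguishable on both cores, so the result from the first pair carried over to the second. It does not show why the swap makes so little difference, and two pairs cannot establish that the same would hold on a third core or in a different assay.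

The compounds shown leave open whether a ring amine such as piperidine or morpholine, or a primary amine, at the end of the chain would give a step beyond the scatter. They also leave open what a shorter or longer chain would do, and which of the several differences between the two cores matters for the read-out.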